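The compounds below may be only part of what the source reports. "The series", "measured", "known", "first", "only" and "open" are said of these compounds alone.

The three measured compounds share one core and differ in the group on its aromatic nitrogen. In an assay for inhibition of MAP kinase-interacting serine/threonine-protein kinase 2 (Homo sapiens), read by luminescence and ADP-Glo, with a stated time of 2 h (on this read-out higher numbers stand for weaker inhibition and lower numbers for stronger inhibition), compound 1 `O=c1ccc(-c2ccc3cn[nH]c3c2)cn1Cc1ccccc1C(F)(F)F` gives 100 nM and compound 3 `Nc1n[nH]c2cc(-c3ccc(=O)n(Cc4cccc(F)c4)c3)ccc12` gives 5 nM. For compound 2 `O=C(N1CCOCC1)n1cc(-c2ccc3cn[nH]c3c2)ccc1=O` the assay reports no number but only a limit, > 2000 nM. That is the limit of > 2000 nM in this assay, at which 1 of the 3 values shown sits. Compound 4 `Nc1cccc(Cn2cc(-c3ccc4cn[nH]c4c3)ccc2=O)c1` differs from compound 2 by 3-aminobenzyl in place of (morpholin-4-yl)carbonyl on an aromatic nitrogen. Among the compounds with values here, no measured step between neighbours is available, yet compound 1 with 100 nM and compound 3 with 5 nM show that other substituents at this nitrogen are measured well inside the range of this assay. Compound 4 is therefore expected to give a number inside the range of this assay, an expected step of an at least 33-fold lower number from compound 2 to compound 4 (1.52 log units; beyond the scatter). Compound 4 is thus estimated at 60 nM, within 15 nM to 250 nM.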

Compound 4, half-maximal inhibitory concentration: 84 nM
Compound 4: middle estimate off by 1.4-fold (0.15 log units), on the low side, within the range that was stated.
By their numbers in this assay, from the lowest: compound 3; then compounds 4 and 1 (each within the scatter of the next). At a limit, above all of these: compound 2.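

In this assay, within the data shown here, 3-aminobenzyl in place of (morpholin-4-yl)carbonyl on the aromatic nitrogen gives an at least 23-fold lower number from compound 2 to compound 4 (1.37 log units; beyond the scatter) as the first step at this position between compounds that differ in one place. The change thus carries a compound from the limit into the measurable range while the core stays the same. The full size of this step cannot be read, because the entry for compound 2 is a limit and not a number: the limit of > 2000 nM in this assay, at which 1 of the 4 values shown sits.

Going by these compounds, what an unsubstituted benzyl or a 3-carboxybenzyl group would give on this nitrogen remains open. So does whether the amine of 3-aminobenzyl contributes to the value of compound 4 at all.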